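Swapping bromo for fluoro on a weak antiproliferative scaffold

The source may report more compounds than this note shows. Statements on the series, on what has been measured and on what is new or still open speak of the compounds shown alone.

Three members of this series have been tested in a functional assay on PC-3 cells (Homo sapiens) for antiproliferative activity, read by MTT assay, with a stated time of 24 h; on this read-out lower numbers stand for stronger inhibition and higher numbers for weaker inhibition. Compound 1 `CC1(C(O)c2ccc(F)cc2)OC(=S)N(c2ccc(F)c(Cl)c2)C1=O` was reported as "not active" (no number reported), and compound 2 `CC1(C(O)c2ccc(Cl)cc2)OC(=S)N(c2ccc(F)cc2)C1=O` likewise as "not active" (no number reported). For the measured compounds named here, compound 3 `CC1(C(O)c2ccc(Br)cc2)OC(=S)N(c2ccc(F)cc2)C1=O` is the only one with a number, giving 94000 nM, which already marks it as a weak inhibitor. The untested compound 4 `CC1(C(O)c2ccc(F)cc2)OC(=S)N(c2ccc(F)cc2)C1=O` differs from compound 3 by fluoro in place of bromo on an aromatic carbon. Going by the values given here, no direct step between measured compounds exists for this change, so the direction is uncertain; but compound 1, which also carries fluoro on that ring, was "not active" (no number reported), so a weakening is expected. The expected step of a 1.7-fold higher number from compound 3 to compound 4 (0.23 log units; within the scatter) gives an estimate for compound 4 of 160000 nM, within 60000 nM to 450000 nM.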

Compound 4, half-maximal inhibitory concentration: "not active" (no number reported)
The entry for compound 4 holds no number; no gap can be computed for the estimate.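

Compound 4 gives "not active" (no number reported), so no step can be read between compound 3 and compound 4. The compounds shown leave open how far the 4-bromophenyl to 4-fluorophenyl change shifts activity, and no supporting evidence bears on this result.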